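Amide series: azido to amino on the benzyl ring

A few compounds are considered here, and "the series" means these few. Any claim that something is new, unique, unknown or untested is made for them only; others in the source may bear on it.

Measured in a functional assay on PC-3 cells (Homo sapiens) for antiproliferative activity, read by MTT assay, with a stated time of 48 h; on this read-out lower numbers stand for stronger inhibition and higher numbers for weaker inhibition:
compound 1 `COc1cc(N(Cc2ccc(C)cc2)C(=O)CSc2nc3ccccc3s2)cc(OC)c1OC`: > 80000 nM
compound 2 `COc1ccc(CN(C(=O)CSc2nc3ccccc3s2)c2cc(OC)c(OC)c(OC)c2)cc1N=[N+]=[N-]`: 14400 nM
compound 3 `COc1ccc(CN(C(=O)CSc2nc3ccccc3s2)c2cc(OC)c(OC)c(OC)c2)cc1`: 8460 nM

The value of compound 1 is a limit of the assay, (the limit of > 80000 nM in this assay, at which 1 of the 3 values shown sits). Among the two numbers, compound 2 stands highest, with compound 3 nearest at a 1.7-fold lower number from compound 2 to compound 3 (0.23 log units; within the scatter). Compound 4 `COc1ccc(CN(C(=O)CSc2nc3ccccc3s2)c2cc(OC)c(OC)c(OC)c2)cc1N` is not yet measured; it differs from compound 2 by amino in place of azido on an aromatic carbon. The step that bears on it is a 1.7-fold lower number from compound 2 to compound 3 (0.23 log units; within the scatter), a small step within the scatter; the steps of an at least 5.5-fold lower number from compound 1 to compound 2 (0.74 log units; beyond the scatter) and an at least 9.4-fold lower number from compound 1 to compound 3 (0.97 log units; beyond the scatter) start from a limit and only bound the change. Replacing azido is therefore expected to move the number little, no step beyond the scatter in either direction. Compound 4 is estimated at 11000 nM, between 4500 nM and 30000 nM, an expected 1.3-fold lower number from compound 2 to compound 4 (0.12 log units; within the scatter).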

Compound 4, half-maximal inhibitory concentration: 7510 nM
Estimate against measurement, compound 4: 1.5-fold (0.17 log units) above, within the range that was stated.
By their numbers in this assay, from the lowest: compounds 4, 3 and 2 (each within the scatter of the next). At a limit, above all of these: compound 1.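

In this assay the steps of a 1.9-fold lower number from compound 2 to compound 4 (0.28 log units; within the scatter) and a 1.1-fold lower number from compound 3 to compound 4 (0.05 log units; within the scatter) leave amino, azido and hydrogen unseparated on the aromatic carbon ortho to a methoxy group. Amino brings a hydrogen-bond donor that azido lacks, and the number of compound 4 still stays within the scatter of compound 2. Compound 1 stands at a limit, so the step of an at least 10-fold lower number from compound 1 to compound 4 (1.02 log units; beyond the scatter) only bounds that change: the limit of > 80000 nM in this assay, at which 1 of the 4 values shown sits.

Going by these compounds, whether a carboxylic acid or an acetamide on this carbon would move the number beyond the scatter stays open.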